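Working notes: sulfonyl substituent, compound 3 to compound 4

The compounds below may be only part of what the source reports. "The series", "measured", "known", "first", "only" and "open" are said of these compounds alone.

Compound 1 `CNS(=O)(=O)c1ccc(C)c(C#Cc2cc(Cl)ccc2OCC(=O)O)c1` gives 10 nM in an assay on CHO cells for displacement of a labelled ligand from prostaglandin D2 receptor 2 (Homo sapiens), read by scintillation counting; on this read-out higher numbers stand for weaker inhibition and lower numbers for stronger inhibition.
Compound 2 `Cc1ccc(S(=O)(=O)CCO)cc1C#Cc1cc(Cl)ccc1OCC(=O)O` gives 19 nM in this assay.
Compound 3 `CCS(=O)(=O)c1ccc(C)c(C#Cc2cc(Cl)ccc2OCC(=O)O)c1` gives 8.6 nM in this assay.

Compound 3 carries the lowest number of the three: a 1.2-fold lower number from compound 1 to compound 3 (0.07 log units; within the scatter) and a 2.2-fold lower number from compound 2 to compound 3 (0.34 log units; beyond the scatter). The gap to compound 1 stays within the scatter, so those two are not separable, and a 1.9-fold higher number from compound 1 to compound 2 (0.28 log units; within the scatter) also stays within it. Compound 4 `Cc1ccc(S(=O)(=O)CC(C)C)cc1C#Cc1cc(Cl)ccc1OCC(=O)O` differs from compound 3 by isopropyl in place of methyl on a saturated chain carbon bound to a sulfonyl sulfur. Among the measured compounds shown here, no measured step replaces one alkyl on the sulfonyl sulfur by a larger alkyl; the steps seen so far exchange the group attached to the sulfonyl sulfur or remove a hydroxy, and none moves far. The change is therefore expected to give no step beyond the scatter, a 1.2-fold higher number from compound 3 to compound 4 (0.07 log units; within the scatter). Compound 4 is estimated at 10 nM in this assay, expected range 4 nM to 25 nM.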

Compound 4, inhibition constant: 3 nM
The estimate for compound 4 lay 3.3-fold (0.52 log units) above the measured number; measured number below the stated range.
By their numbers in this assay, from the lowest: compound 4; then compounds 3, 1 and 2 (each within the scatter of the next, the first and the last beyond it).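

Isobutyl on the sulfonyl sulfur separates from ethyl, with a 2.9-fold lower number from compound 3 to compound 4 (0.46 log units; beyond the scatter), and from methylamino, with a 3.3-fold lower number from compound 1 to compound 4 (0.52 log units; beyond the scatter), although those two earlier groups could not be separated from each other. The gap to the 2-hydroxyethyl group is wider, with a 6.3-fold lower number from compound 2 to compound 4 (0.80 log units; beyond the scatter), so branched alkyl at this position gives a clear step where the earlier exchanges moved little. No data on hand explain this step.

From the compounds shown here alone, whether a longer chain or a cyclohexyl ring on the sulfonyl sulfur would extend the step remains open. So does the effect of an amine at the end of the chain.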